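This account rests on a few compounds, and the source may have more. Where it says the series, first, only, none or still open, it means among the compounds named here.

Measured compounds:
compound 1 `COc1ccc(/C=N/NC(=O)Nc2cc3c(Nc4ccc(F)c(Cl)c4)ncnc3cc2O[C@H]2CCOC2)cc1` — 27300 nM
compound 2 `COc1ccc(/C=N/NC(=O)Nc2cc3c(Nc4ccc(F)c(Cl)c4)ncnc3cc2O[C@H]2CCOC2)c(OC)c1OC` — 33800 nM
compound 3 `COc1ccc(/C=N/NC(=O)Nc2cc3c(Nc4ccc(F)c(Cl)c4)ncnc3cc2OC)cc1` — 8140 nM

All three were run in a functional assay on MCF7 cells (Homo sapiens) for cytotoxicity, read by MTT assay, with a stated time of 72 h; a higher number here means a weaker inhibitor, a lower number a stronger inhibitor. Compound 4 `COc1cc2ncnc(Nc3ccc(F)c(Cl)c3)c2cc1NC(=O)N/N=C/c1ccc(OC)c(OC)c1OC` has not yet been measured there.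

The change from compound 3 to compound 4 is 2,3,4-trimethoxyphenyl in place of 4-methoxyphenyl on a carbon with a double bond to nitrogen. The same change has already been made once in the series, from compound 1 to compound 2, as 2,3,4-trimethoxyphenyl in place of 4-methoxyphenyl on a carbon with a double bond to nitrogen; the two place descriptions agree word for word, so this is the same change on a different core. There it gave a 1.2-fold higher number from compound 1 to compound 2 (0.09 log units; within the scatter).

The cores of compound 1 and compound 3 differ by methyl in place of oxolan-3-yl on an oxygen on an aromatic ring, which gave a 3.4-fold lower number from compound 1 to compound 3 (0.53 log units; beyond the scatter). Compound 3 therefore stands as the lowest of the three measured values, beyond the scatter from both compound 1 and compound 2.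

For the measured compounds named here, the step from compound 3 to compound 4 is expected to be about the size of the earlier one, a 1.2-fold higher number from compound 3 to compound 4 (0.08 log units; within the scatter), because the only precedent is a 1.2-fold higher number from compound 1 to compound 2 (0.09 log units; within the scatter), a within-scatter shift. A single precedent leaves the range wide. For compound 4 in this assay the estimate is 9800 nM, with a band from 4000 nM to 24000 nM.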

Compound 4, half-maximal inhibitory concentration: "not active" (no number reported)
Compound 4: no number reported, and the estimate cannot be compared.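

For the compounds shown here, compound 4 is recorded in this assay as "not active" with no number, so no step from compound 3 to compound 4 can be read. The compounds shown leave open how the 2,3,4-trimethoxyphenyl change compares on the core of compound 3 and the core of compound 1. No evidence bears on this result.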